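The source may hold more compounds than are shown below. What is called first, only, known or untested is meant among the compounds shown, and "the series" means these compounds.

Compound 1 `Cc1cc(NC(=O)Nc2cccc([N+](=O)[O-])c2)c2ccccc2n1`: > 25000 nM
Compound 2 `Cc1cc(NC(=O)Nc2cccc3nsnc23)c2ccccc2n1`: > 25000 nM
Compound 3 `Cc1cc(NC(=O)Nc2ccccc2C(F)(F)F)c2ccccc2n1`: > 25000 nM

All three compounds were tested in an ADME assay on Raji cells (Homo sapiens) for cytotoxicity, with a stated time of 72 h; a higher number here means that more compound is needed for the effect, a lower number that less compound is needed. Each entry is a limit of the assay and not a number. Compound 1 therefore has no exact position and stands at the limit of > 25000 nM in this assay, at which 3 of the 3 values shown sit. Going by the values given here, with no number to compare, the data contain no measured step from one compound to another.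

The next compound, compound 4 `Cc1cc(NC(=O)Nc2cccc(OC(F)(F)F)c2)c2ccccc2n1`, keeps the core of compound 1 and has trifluoromethoxy in place of nitro on an aromatic carbon, meta to a large group: trifluoromethoxy in place of nitro on an aromatic carbon. The expectation for this change in this assay is no step beyond the usual scatter, and the most likely result is another limit. That expectation rests on compound 1 and its two companions, which all sit at the limit of > 25000 nM in this assay, at which 3 of the 3 values shown sit. The expected change is a number no higher from compound 1 to compound 4 (the limit leaves the size open). For compound 4 the estimated value is 25000 nM, with an expected range from 10000 nM to 40000 nM.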

Compound 4, half-maximal effective concentration: 9000 nM
The estimate for compound 4 lay 2.8-fold (0.44 log units) above the measured number; measured number below the stated range.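

In this assay, putting trifluoromethoxy in place of nitro on an aromatic carbon, meta to a large group, gives an at least 2.7-fold lower number from compound 1 to compound 4 (0.44 log units; beyond the scatter). Going by these compounds, the value of compound 1 is a limit, and the full size of this step stays unknown. Compound 4 is the only one of the four compounds with an exact number, which shows that a change at this one place on the shared core can bring the cytotoxicity into the measurable range: the limit of > 25000 nM in this assay, at which 3 of the 4 values shown sit.

The compounds shown leave open whether the effect is special to trifluoromethoxy, or whether another group at this same place, such as an amine or a carboxylic acid, would also give a number. With a single exact value, they also cannot show any trend across groups at this place.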